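Replacing an Ethoxyphenyl by a Catechol on a Shared Core

The source may report more compounds than this note shows. Statements on the series, on what has been measured and on what is new or still open speak of the compounds shown alone.

Compound 1 `CCOc1ccc(-c2cc(=O)c3c(o2)C(CC)(CC)C(=O)C(CC)=C3O)cc1` was tested in a functional assay on KB cells (Homo sapiens) for antiproliferative activity, read by sulforhodamine B assay, with a stated time of 3 days; a lower number here means that less compound is needed, a higher number that more compound is needed for the effect. In this assay compound 1 gives only a limit, > 52.4 uM, and no number. Two related compounds do give numbers. Compound 2 `CCC1=C(O)c2c(oc(-c3ccc(OC)c(C)c3C)cc2=O)C(CC)(CC)C1=O` gives 5.43 uM in this assay. Compound 3 `CCC1=C(O)c2c(oc(-c3ccc(OC)c(OC)c3OC)cc2=O)C(CC)(CC)C1=O` gives 9.4 uM in this assay. Compound 1 therefore stands at the limit of > 52.4 uM in this assay, at which 1 of the 3 values shown sits, the only one of the three without a measured value, while compound 2 and compound 3 lie within the usual scatter of each other, so nothing can be said about their order.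

Compound 4 `CCC1=C(O)c2c(oc(-c3ccc(O)c(O)c3)cc2=O)C(CC)(CC)C1=O` has not yet been measured in this assay. It differs from compound 1 in one place: 3,4-dihydroxyphenyl in place of 4-ethoxyphenyl on an aromatic carbon. Going by the values given here, no pair of measured compounds shows this same change, so the size of the step is judged from the three values alone. Since the other two substituted phenyls in this place give numbers while compound 1 sits at the limit of > 52.4 uM in this assay, at which 1 of the 3 values shown sits, a step toward less compound needed is expected, but it may also be small or stay at the limit.

Compound 4 is expected to give about 20 uM in this assay, with a range from 5 uM to 60 uM. This estimate means a step from compound 1 to compound 4 of an at least 2.6-fold lower number from compound 1 to compound 4 (0.41 log units; beyond the scatter), expected to lie beyond the scatter.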

Compound 4, concentration for half-maximal effect: 10 uM
Beside the measured number, compound 4's estimate is 2.0-fold (0.30 log units) above it; the range from low to high includes it.
By their numbers in this assay, from the lowest: compounds 2, 3 and 4 (each within the scatter of the next). At a limit, above all of these: compound 1.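

In this assay, this place on the shared core now has a step that can be read: 3,4-dihydroxyphenyl in place of 4-ethoxyphenyl gives an at least 5.2-fold lower number from compound 1 to compound 4 (0.71 log units; beyond the scatter). The earlier compounds shown here held no pair differing in one place, and this change shows that the group here alone can decide whether a compound stays at the limit or gives a number, while compound 4 lies within the scatter of compound 2 and compound 3, so these three differently substituted phenyls cannot be put in order. Going by these compounds alone, the step is only a bound, and its true size stays open, since compound 1 remains the one compound with a limit and no number: the limit of > 52.4 uM in this assay, at which 1 of the 4 values shown sits.

The compounds shown do not separate the loss of the ethoxy chain from the arrival of the two hydroxyl groups, and they do not tell whether both hydroxyl groups are needed. A phenyl carrying a single hydroxyl, or one carrying an amine or a carboxylic acid, in this same place would be needed to tell these apart.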